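A Second Allyl Group Added to Compound 2

A few compounds are considered here, and "the series" means these few. Any claim that something is new, unique, unknown or untested is made for them only; others in the source may bear on it.

Compound 1 `C=CC(C)(C)c1cc(-c2cccc([N+](=O)[O-])c2)ccc1O` gives 45100 nM in a functional assay on Lewis lung carcinoma cells (Mus musculus) for antiproliferative activity, read by MTT assay, with a stated time of 24 h; on this read-out higher numbers stand for weaker inhibition and lower numbers for stronger inhibition. Compound 3 `C=CCc1cc(-c2cccc(C(F)(F)F)c2)ccc1O` gives 65900 nM. Compound 2 `C=CCc1cc(-c2cccc([N+](=O)[O-])c2)ccc1O` reaches only the limit of > 100000 nM, not a number.

Compound 2 thus stands at the weak end of the values shown, at the point where (the limit of > 100000 nM in this assay, at which 1 of the 3 values shown sits). Compound 4 `C=CCc1cc(-c2cccc([N+](=O)[O-])c2)cc(CC=C)c1O` differs from it by allyl in place of hydrogen on an aromatic carbon. Going by the values given here, no measured step matches this change directly. The step of an at least 2.2-fold higher number from compound 1 to compound 2 (0.34 log units; beyond the scatter) shows that less carbon on the aromatic carbon went with weaker inhibition, while an at least 1.5-fold lower number from compound 2 to compound 3 (0.18 log units; that floor lies within the scatter) stays within the scatter. Adding carbon is therefore expected to lower the number somewhat, a step of about an at least 1.6-fold lower number from compound 2 to compound 4 (0.22 log units; that floor lies within the scatter). Compound 4 is estimated at 60000 nM, between 20000 nM and 200000 nM.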

Compound 4, half-maximal inhibitory concentration: 56500 nM
Compound 4: the middle estimate sits 1.1-fold (0.03 log units) above what was measured; low and high end bracket the measured number.
By their numbers in this assay, from the lowest: compounds 1, 4 and 3 (each within the scatter of the next). At a limit, above all of these: compound 2.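

Going by these compounds alone, compound 1, compound 2 and compound 3 all carry hydrogen on this aromatic carbon, ortho to a hydroxy group, so compound 4 gives the first reading of a group there. In this assay, from the compounds shown here alone, the change gives an at least 1.7-fold lower number from compound 2 to compound 4 (0.24 log units; that floor lies within the scatter), so the true size of the step stays unknown. Compound 2 stands at a limit of the assay, not at a number: the limit of > 100000 nM in this assay, at which 1 of the 4 values shown sits.

The compounds shown leave open whether an amine, a carboxylic acid or a longer chain on this carbon would read differently from allyl. They also leave open what allyl does here when trifluoromethyl replaces nitro.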